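From Methyl to Trifluoromethyl: One Small Swap

The compounds below may be only part of what the source reports. "The series", "measured", "known", "first", "only" and "open" are said of these compounds alone.

A single measured number anchors this small set. In a physicochemical assay for lipophilicity, using the shake flask method, in phosphate buffer, measured as octanol-water partition, with a stated time of 24 h, at pH 7.4, tested at 100 uM (on this read-out lower numbers stand for lower lipophilicity and higher numbers for higher lipophilicity), compound 2 (`Cc1ccccc1-c1cccc(COc2ccc(S(=O)(=O)CC(=O)O)cc2)c1`) gives 2.35, and no other measured value stands beside it. Compound 1 (`COc1cc(C)c(-c2cccc(COc3ccc4c(c3)S(=O)(=O)CC4CC(=O)O)c2)c(C)c1`) offers no comparison, since the entry for compound 1 reads "not determined" (no result reported). The open question is compound 3 (`O=C(O)CS(=O)(=O)c1ccc(OCc2cccc(-c3ccccc3C(F)(F)F)c2)cc1`), which has not yet been measured. It differs from compound 2 in one place, with trifluoromethyl in place of methyl on an aromatic carbon, ortho to a large group: trifluoromethyl in place of methyl on an aromatic carbon. Within the data shown here, no measured pair here shows this swap, so the expectation rests on the structural change alone and carries real uncertainty. A modest rise in this assay is expected, estimated as a number 0.40 log units higher from compound 2 to compound 3 (beyond the scatter). For compound 3 the estimated value is 2.75, with an expected range of 2.35 to 3.15.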

Compound 3, distribution coefficient: 2.95
Estimate against measurement, compound 3: 0.20 log units below, and the stated range covers the measured number.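

In this assay, putting trifluoromethyl in place of methyl on an aromatic carbon, ortho to a large group, gives a number 0.60 log units higher from compound 2 to compound 3 (beyond the scatter). Among these compounds, this is the first measured step in the set, and it shows that the read-out responds to a change at this one position, by more than repeat measurements would normally differ. The data offer no measured explanation for the size of this step.

This single pair cannot show whether the same swap would give a similar step elsewhere on the ring or on the core of compound 1. It also leaves open where a chlorine atom, a methoxy group or a nitrile at this position would fall relative to methyl and trifluoromethyl.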